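Moving the chlorine and methyl around the anilide ring

The source may hold more compounds than are shown below. What is called first, only, known or untested is meant among the compounds shown, and "the series" means these compounds.

Three sulfonamides sharing one core have been measured in a functional assay on cells (leukaemia cell line, Homo sapiens) for inhibition, read by sulforhodamine B assay, with a stated time of 48 h; a higher number here means a weaker inhibitor of growth, a lower number a stronger inhibitor of growth. Compound 1 `O=S(=O)(Nc1cccc(Cl)c1)c1ccc(-c2cnc(C3CC3)o2)cc1` gives 477 nM. Compound 2 `Cc1cc(NS(=O)(=O)c2ccc(-c3cnc(C4CC4)o3)cc2)ccc1Cl` gives 216 nM, and compound 3 `COc1cc(NS(=O)(=O)c2ccc(-c3cnc(C4CC4)o3)cc2)ccc1F` gives 328 nM. Compound 2 has the lowest of the three numbers, though only its step from compound 1 is beyond the scatter: a 2.2-fold lower number from compound 1 to compound 2 (0.34 log units; beyond the scatter). The other two steps, a 1.5-fold lower number from compound 1 to compound 3 (0.16 log units; within the scatter) and a 1.5-fold higher number from compound 2 to compound 3 (0.18 log units; within the scatter), both fall within the scatter, so compounds 2 and 3 cannot be ordered against each other.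

Compound 4 `Cc1cc(Cl)cc(NS(=O)(=O)c2ccc(-c3cnc(C4CC4)o3)cc2)c1` has the same atoms as compound 2, joined differently: 3-chloro-5-methylphenyl in place of 4-chloro-3-methylphenyl on a sulfonamide nitrogen. Among the compounds with values here, of the measured steps, only the one from compound 1 to compound 2 bears on a change in the chloro and methyl pattern on this ring, and it was modest; the swap from compound 2 to compound 3 was within the scatter. On that basis no step beyond the scatter is expected in this assay, with perhaps a slight drift back toward the number of compound 1. Compound 4 is therefore estimated at 300 nM, expected to lie between 150 nM and 650 nM, meaning a step of a 1.4-fold higher number from compound 2 to compound 4 (0.14 log units; within the scatter).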

Compound 4, concentration for 50% growth inhibition: 175 nM
Compound 4: the middle estimate sits 1.7-fold (0.23 log units) above what was measured; the measured number falls inside the stated range.
By their numbers in this assay, from the lowest: compounds 4, 2, 3 and 1 (each within the scatter of the next, the first and the last beyond it).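

Moving the chlorine and methyl from the 4-chloro-3-methylphenyl to the 3-chloro-5-methylphenyl pattern on the sulfonamide nitrogen gives no readable change in this assay, with a 1.2-fold lower number from compound 2 to compound 4 (0.09 log units; within the scatter), and the comparison with the 4-fluoro-3-methoxyphenyl group, a 1.9-fold lower number from compound 3 to compound 4 (0.27 log units; within the scatter), also stays within the scatter, so these three groups cannot be ordered against one another. Within the data shown here, the new information comes from the single change of methyl in place of hydrogen on an aromatic carbon, a 2.7-fold lower number from compound 1 to compound 4 (0.44 log units; beyond the scatter), a modest step beyond the scatter that leaves the chlorine of compound 1 where it stands, which shows that the step seen with compound 2 does not depend on the chlorine sitting where compound 2 carries it. Nothing available on these compounds accounts for either the step or the lack of one.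

As far as these compounds go, whether the methyl itself can be varied remains open, for instance by ethyl, or by an amine or a carboxylic acid in its place. From the compounds shown here alone, it is also open whether the methyl of compound 4 would hold its effect with the chlorine replaced by bromine or by hydrogen.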